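The source may hold more compounds than are shown below. What is called first, only, known or untested is meant among the compounds shown, and "the series" means these compounds.

Measured so far in an assay on IM-9 cells for binding affinity to Substance-P receptor (Homo sapiens); on this read-out lower numbers stand for stronger inhibition and higher numbers for weaker inhibition:
- Compound 1 `Cc1ccccc1-c1c(C(=O)N(C)Cc2ccccc2Cl)n(C)c(=O)c2ccccc12` gives 19 nM
- Compound 2 `Cc1ccccc1-c1c(C(=O)N(C)Cc2cc(C(F)(F)F)cc(C(F)(F)F)c2)n(C)c(=O)c2ccccc12` gives 1.3 nM
- Compound 3 `Cc1cc(C)cc(CN(C)C(=O)c2c(-c3ccccc3C)c3ccccc3c(=O)n2C)c1` gives 32 nM

Among these three numbers compound 1 stands second highest. Its nearest neighbour is compound 3, which differs from it by a 1.7-fold higher number from compound 1 to compound 3 (0.23 log units; within the scatter), a shift that stays within the scatter of the assay. Compound 2 lies furthest away, with a number far lower than that of compound 1, a gap well beyond the scatter.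

Compound 4 `COc1ccccc1CNC(=O)c1c(-c2ccccc2C)c2ccccc2c(=O)n1C` shares the core of compound 1 but differs at the carbonyl carbon: a group of 10 heavy atoms (8 carbon, 1 nitrogen, 1 oxygen; one six-membered aromatic ring of carbon only) in place of a group of 10 heavy atoms (8 carbon, 1 nitrogen, 1 chlorine; one six-membered aromatic ring of carbon only), on a carbonyl carbon. The entering group thus brings one hydrogen-bond donor and one hydrogen-bond acceptor where the leaving group had none.

For the measured compounds named here, no measured step covers this change. Going by the values given here, the only single-point step, from compound 1 to compound 3, swaps the aromatic substituents and stays within the scatter; the change to compound 4 also removes the methyl from the amide-type nitrogen, which none of the measured compounds probes. The expectation for compound 4 is therefore uncertain, with a weaker binding number judged somewhat more likely, so a step of a 3.2-fold higher number from compound 1 to compound 4 (0.50 log units; beyond the scatter) is estimated. For compound 4 a value of 60 nM is expected, within a range from 12 nM to 300 nM.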

Compound 4, half-maximal inhibitory concentration: 470 nM
Estimate against measurement, compound 4: 7.8-fold (0.89 log units) below; the measured number lies above the stated range.
By their numbers in this assay, from the lowest: compound 2; then compounds 1 and 3 (each within the scatter of the next); then compound 4.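

Replacing the group on the carbonyl carbon with (2-methoxybenzyl)amino gives, in this assay, a 25-fold higher number from compound 1 to compound 4 (1.39 log units; beyond the scatter), whereas the earlier swap of aromatic substituents gave only a 1.7-fold higher number from compound 1 to compound 3 (0.23 log units; within the scatter). This position therefore does not accept every change, and a group of the same heavy-atom count can still shift the number strongly. The new group differs in two ways at once, with an amide hydrogen in place of the methyl on the nitrogen and a methoxy group in place of the chlorine, and no measurement at hand explains the shift.

Still open, on these data alone, is which of these two differences carries the change, something a methoxy compound keeping the nitrogen methyl would help to separate. Also open, as far as these compounds go, is how a longer chain between the amide nitrogen and the ring, or an amine on that ring, would behave.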